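Ether to thioether at the core of compound 3

The source may hold more compounds than are shown below. What is called first, only, known or untested is meant among the compounds shown, and "the series" means these compounds.

Measured compounds in a functional assay on SF-295 cells (Homo sapiens) for inhibition, read by sulforhodamine B assay, with a stated time of 48 h; on this read-out lower numbers stand for stronger inhibition of growth and higher numbers for weaker inhibition of growth:
compound 1, `Nc1cc(N)c2nc(-c3ccccc3)c(Oc3ccc(Cl)c(Cl)c3)nc2c1`, 30900 nM
compound 2, `COc1ccc(Sc2nc3cc(N)cc(N)c3nc2-c2ccccc2)cc1`, value reported only as a limit
compound 3, `Nc1cc(N)c2nc(-c3ccccc3)c(Oc3ccc(F)cc3)nc2c1`, 38900 nM

Compound 3 sits at the highest of the two numbers shown. Its nearest neighbour is compound 1, and the step of a 1.3-fold higher number from compound 1 to compound 3 (0.10 log units; within the scatter) lies within the scatter. For compound 2 this assay reports only a limit, < 100000 nM. That limit, (the limit of < 100000 nM in this assay, at which 1 of the 3 values shown sits), leaves the step that the limit leaves unreadable from compound 1 to compound 2 and likewise the step that the limit leaves unreadable from compound 2 to compound 3 without a readable size.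

Compound 4, `Nc1cc(N)c2nc(-c3ccccc3)c(Sc3ccc(F)cc3)nc2c1`, is not yet measured. It differs from compound 3 in one place: (4-fluorophenyl)sulfanyl in place of 4-fluorophenoxy on an aromatic carbon. The two measured steps that also exchange oxygen for sulfur at this position, from compound 1 to compound 2 and from compound 2 to compound 3, both run into the limit of compound 2 and so give no size. Among the measured compounds shown here, the one readable step, a 1.3-fold higher number from compound 1 to compound 3 (0.10 log units; within the scatter), changes the substituent on the oxygen and not the linking atom, so it bears only indirectly on this change.

With no readable step for the linking-atom exchange, the expectation for compound 4 is a step of a 1.2-fold higher number from compound 3 to compound 4 (0.06 log units; within the scatter), that is none beyond the scatter, with a wide range. Compound 4 is therefore estimated at 45000 nM, between 15000 nM and 100000 nM.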

Compound 4, concentration for total growth inhibition: 30200 nM
Beside the measured number, compound 4's estimate is 1.5-fold (0.17 log units) above it; the range from low to high includes it.
By their numbers in this assay, from the lowest: compounds 4, 1 and 3 (each within the scatter of the next).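

In this assay the exchange of the linking atom on this aromatic carbon now has a readable size, a 1.3-fold lower number from compound 3 to compound 4 (0.11 log units; within the scatter), so with the 4-fluorophenyl group held constant, the oxygen and sulfur links cannot be told apart on the shared core. The exchange of 3,4-dichlorophenoxy for (4-fluorophenyl)sulfanyl, which alters the linking atom and the ring substituents in a single step, gives a 1.0-fold lower number from compound 1 to compound 4 (0.01 log units; within the scatter), so this larger exchange also stays inside the scatter. Compound 2 is reported only as a limit, and the steps that involve it, including the one to compound 4, cannot be read: the limit of < 100000 nM in this assay, at which 1 of the 4 values shown sits.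

Every readable step at this position lies within the scatter, so the compounds shown do not tell whether any group here can move the number beyond it, nor what the methoxy group on the sulfur-linked ring contributes. A sulfonyl link, an amine link, or a carboxylic acid or longer chain on the ring in place of fluoro would test whether this position tolerates more than the exchanges seen so far.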